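Shortening the ester side chain of compound 2

A few compounds are considered here, and "the series" means these few. Any claim that something is new, unique, unknown or untested is made for them only; others in the source may bear on it.

Two esters on a shared core have so far been measured in an ADME assay on a cell-free system (plasma, Homo sapiens) for metabolic stability, read by LC-MS; a lower number here means that the compound disappears faster, a higher number that the compound lasts longer. Compound 1 (`NCc1ccc(C(=O)Nc2ccncc2F)cc1-c1cccc(C(=O)OCC2CC2)c1`) gives 0.3 h there, and compound 2 (`NCc1ccc(C(=O)Nc2ccncc2F)cc1-c1cccc(C(=O)OCC2CCCCO2)c1`) gives 0.117 h as the lower of the two numbers. The next structure, compound 3 (`COC(=O)c1cccc(-c2cc(C(=O)Nc3ccncc3F)ccc2CN)c1`), carries hydrogen in place of oxan-2-yl on a saturated chain carbon bound to an oxygen next to a carbonyl group, so that ((oxan-2-yl)methoxy)carbonyl becomes methoxycarbonyl. Within the data shown here, only one measured step bears on this change. That step, a 2.6-fold lower number from compound 1 to compound 2 (0.41 log units; beyond the scatter), is modest and falls at the same place, with oxan-2-yl in place of cyclopropyl. Among the measured compounds shown here, it is a single pair and no measured compound has hydrogen at that place, so it offers only a loose guide. Reading that step in reverse, the expectation is a modest rise, an estimated 3.4-fold higher number from compound 2 to compound 3 (0.53 log units; beyond the scatter) in this assay with wide uncertainty. For compound 3 the estimated half-life is 0.4 h with an expected range from 0.13 h to 1.2 h for repeat measurements.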

Compound 3, half-life: 1.08 h
Compound 3: middle estimate off by 2.7-fold (0.43 log units), on the low side, within the range that was stated.
By their numbers in this assay, from the lowest: compound 2; then compound 1; then compound 3.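

In this assay, taking the ring away altogether at this place, on a saturated chain carbon bound to an oxygen next to a carbonyl group, gives a 9.2-fold higher number from compound 2 to compound 3 (0.97 log units; beyond the scatter) and also a 3.6-fold higher number from compound 1 to compound 3 (0.56 log units; beyond the scatter) as the second step to the same ester. The earlier pair had shown only that one ring in place of another shifts the half-life, whereas these steps show that the methoxycarbonyl ester, with hydrogen at this place and no ring, lasts longer than either ring-bearing ester, and each step lies beyond the usual scatter. The three esters now fall into a single order, with oxan-2-yl lowest, cyclopropyl in the middle and hydrogen highest, although nothing available gives a reason for that order.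

Three compounds cannot show whether this order depends on the ring itself or on some other feature of the groups at this place. An ethyl group or a longer straight chain in place of methyl, or a carboxylic acid or an amide in place of the ester, would test how far the rise in half-life extends beyond the methoxycarbonyl ester.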